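Swapping Methyl for Chloro on a Fused Aromatic Ring

A few compounds are considered here, and "the series" means these few. Any claim that something is new, unique, unknown or untested is made for them only; others in the source may bear on it.

Compound 1, `O=C(CCCc1ccccc1)Nc1nc2cc(Cl)ccc2c(=O)s1`: in an assay on CHO cells for displacement of a labelled ligand from adenosine receptor A2b (Homo sapiens), read by scintillation counting, with a stated time of 75 min (a lower number here means a stronger inhibitor, a higher number a weaker inhibitor), compound 1 gives > 1000 nM, a limit of the assay and not a number.
Compound 2, `Cc1ccc2nc(NC(=O)CCCc3ccccc3)sc(=O)c2c1`: in this assay compound 2 gives 408 nM.

Among the measured compounds shown here, compound 2 therefore stands alone as the one compound with an actual number; the other entry is only a limit, (the limit of > 1000 nM in this assay, at which 1 of the 2 values shown sits). Compound 3, `O=C(CCCc1ccccc1)Nc1nc2ccc(Cl)cc2c(=O)s1`, has not been measured. It differs from compound 2 by chloro in place of methyl on an aromatic carbon, and the change is as small as a change can be: one heavy atom leaves, one heavy atom enters, with no ring, no donor, no acceptor and no charge added or removed. For the measured compounds named here, compound 1 also carries a chloro group, but on another carbon of the same ring, and no step links it to either compound 2 or compound 3; its value and that of compound 2 show only that one is a limit and the other a number.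

Going by the values given here, with no measured step covering a methyl-to-chloro swap, the expectation can only be cautious: a step from compound 2 to compound 3 of about a 1.2-fold lower number from compound 2 to compound 3 (0.07 log units; within the scatter) in this assay, that is, little change beyond the scatter, perhaps a slight gain. Compound 3 is thus expected to give about 350 nM, most likely between 150 nM and 900 nM.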

Compound 3, inhibition constant: > 1000 nM
Compound 3: a limit, no number (the forecaster's own chance of this, stated with the estimate: 20%); middle value at least 2.8-fold (0.45 log units) from the limit.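

The swap of methyl for chloro adds no ring, donor, acceptor or charge, yet at this position it is not a neutral exchange: in this assay it gives an at least 2.4-fold higher number from compound 2 to compound 3 (0.38 log units; beyond the scatter). Of the compounds shown, only compound 2, with methyl on this carbon, yields a readable number. The entry for compound 3 is a limit and not a number, so the step gives only a minimum size, and the two chloro compounds, whose comparison cannot be read, cannot be put in order: the limit of > 1000 nM in this assay, at which 2 of the 3 values shown sit.

As far as these compounds go, how far compound 3 really lies from compound 2 stays unknown, as does whether the readable value is special to methyl or would also hold for other small groups on this carbon. An ethyl group, a methoxy group, a fluoro group or an amine at the same carbon would show whether the loss belongs to chloro alone, and a longer chain on the amide would show whether the shared core can tolerate change elsewhere.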